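The source may hold more compounds than are shown below. What is called first, only, known or untested is meant among the compounds shown, and "the series" means these compounds.

Among the measured compounds shown here, compound 2 `COc1cc2c(Oc3ccc(NC(=O)c4nn(-c5ccccc5OC(F)(F)F)c(=O)cc4C)cc3F)ccnc2cc1OCCCN1CCC(C)CC1` gives the lower of the two numbers measured so far in a functional assay on MKN-45 cells (Homo sapiens) for inhibition, read by MTT assay, with a stated time of 72 h (a higher number here means a weaker inhibitor, a lower number a stronger inhibitor), namely 70 nM; compound 1 `COc1cc2c(Oc3ccc(NC(=O)c4nn(-c5ccccc5C)c(=O)cc4C)cc3F)ccnc2cc1OCCCN1CCC(C)CC1` gives 1290 nM. For the measured compounds named here, the only measured step, an 18-fold lower number from compound 1 to compound 2 (1.27 log units; beyond the scatter), shows that changing the group on this phenyl ring can move the number a great deal. Compound 3 `COc1cc2c(Oc3ccc(NC(=O)c4nn(-c5cccc(F)c5)c(=O)cc4C)cc3F)ccnc2cc1OCCCN1CCC(C)CC1` carries the change (3-fluorophenyl in place of 2-(trifluoromethoxy)phenyl on an aromatic nitrogen). Going by the values given here, since no measured step covers a 3-fluorophenyl here, the direction is uncertain, and a step of a 4.3-fold higher number from compound 2 to compound 3 (0.63 log units; beyond the scatter) toward a higher number is expected. Compound 3 is estimated at 300 nM, within a range from 60 nM to 1500 nM.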

Compound 3, half-maximal inhibitory concentration: 140 nM
Compound 3: the middle estimate sits 2.1-fold (0.33 log units) above what was measured; low and high end bracket the measured number.
By their numbers in this assay, from the lowest: compounds 2 and 3 (each within the scatter of the next); then compound 1.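

In this assay, a 2.0-fold higher number from compound 2 to compound 3 (0.30 log units; within the scatter) shows that a low number at this aromatic nitrogen does not depend on the larger 2-(trifluoromethoxy)phenyl, since the smaller 3-fluorophenyl cannot be told apart from it. Meanwhile, a 9.2-fold lower number from compound 1 to compound 3 (0.96 log units; beyond the scatter) leaves 2-methylphenyl as the group that stands apart among the three. Nothing available explains why these groups compare this way. Still open, as far as these compounds go, is how a plain phenyl, or a phenyl carrying an amine or a nitrile, would behave at this position.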